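The source may report more compounds than this note shows. Statements on the series, on what has been measured and on what is new or still open speak of the compounds shown alone.

Measured so far in an assay for inhibition of high affinity nerve growth factor receptor (Homo sapiens), read by HTRF, with a stated time of 30 min, in the presence of a further agent that is not named here; a higher number here means a weaker inhibitor, a lower number a stronger inhibitor: compound 1 `Cc1cc(Nc2nc(NCc3ccc(Br)cc3)nc3ccccc23)n[nH]1`, 180 nM; compound 2 `Cc1cc(Nc2nc(NCc3ccc(C(F)(F)F)cc3)nc3ccccc23)n[nH]1`, 1400 nM; compound 3 `Cc1cc(Nc2nc(NCc3ccc(OC(F)(F)F)cc3)nc3ccccc23)n[nH]1`, 4100 nM.

Compound 1 holds the lowest number of the three in this assay; the nearest is a 7.8-fold higher number from compound 1 to compound 2 (0.89 log units; beyond the scatter), the furthest a 23-fold higher number from compound 1 to compound 3 (1.36 log units; beyond the scatter). Compound 4 `Cc1cc(Nc2nc(NCc3ccccc3F)nc3ccccc23)n[nH]1` differs from compound 1 by 2-fluorophenyl in place of 4-bromophenyl on a saturated chain carbon bound to a nitrogen on an aromatic ring. Within the data shown here, the two measured steps from compound 1 each swap the bromo group for another group and each raise the number beyond the scatter, but neither moves the substituent to a different place on the ring, so the change to compound 4 has no direct precedent; the steps only suggest that leaving the bromo group tends to cost. The step is therefore expected to be a 3.3-fold higher number from compound 1 to compound 4 (0.52 log units; beyond the scatter), with wide uncertainty. Compound 4 is estimated at 600 nM, in the range 150 nM to 2500 nM.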

Compound 4, half-maximal inhibitory concentration: 110 nM
The estimate for compound 4 lay 5.5-fold (0.74 log units) above the measured number, outside the stated range (below it).
By their numbers in this assay, from the lowest: compounds 4 and 1 (each within the scatter of the next); then compound 2; then compound 3.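

In this assay the swap of 4-bromophenyl for 2-fluorophenyl on this saturated chain carbon stays within the scatter (a 1.6-fold lower number from compound 1 to compound 4 (0.21 log units; within the scatter)). The earlier replacements of bromo with trifluoromethyl (a 7.8-fold higher number from compound 1 to compound 2 (0.89 log units; beyond the scatter)) and trifluoromethoxy (a 23-fold higher number from compound 1 to compound 3 (1.36 log units; beyond the scatter)) both cost beyond the scatter, so leaving the bromo group does not always cost. No measurement at hand explains this result.

This change alters both the halogen and its place on the ring, so the two contributions cannot be separated. From the compounds shown here alone, whether an amine or a carboxylic acid on the benzyl ring would be tolerated remains open.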